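Swapping a large ether side chain for acetyl on a coumarin-type core

The source may hold more compounds than are shown below. What is called first, only, known or untested is meant among the compounds shown, and "the series" means these compounds.

Measured so far:
- compound 1, `CCCOc1cc(=O)oc2cc(OCc3ccccc3)ccc12`: 575 nM
- compound 2, `CCOc1cc(=O)oc2cc(OCc3cccc(Br)c3)ccc12`: 126 nM
- compound 3, `CCOC(=O)COc1cc(=O)oc2cc(OCc3cccc(Cl)c3)ccc12`: 1820 nM

All three compounds share one core and were tested in an assay on isolated protein (strain Sprague-Dawley) for inhibition of Amine oxidase [flavin-containing] B (Rattus norvegicus), read by spectrophotometry, with a stated time of 5 min; a higher number here means a weaker inhibitor, a lower number a stronger inhibitor. Among them, compound 3 gives the highest number, 1820 nM, and its distance to both compound 1 and compound 2 lies beyond the usual scatter, so it is the weakest inhibitor of the three. Compound 2, with 126 nM, stands furthest from it.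

Compound 4, `CC(=O)c1cc(=O)oc2cc(OCc3cccc(Cl)c3)ccc12`, has not been measured yet. It differs from compound 3 in one place: acetyl in place of (ethoxycarbonyl)methoxy on an aromatic carbon. The group that leaves is by far the larger of the two, and the smaller side chains present in compound 1 and compound 2 go along with lower numbers than compound 3 shows, though neither of those is an acetyl, so the comparison is loose.

On that basis compound 4 is expected to be a stronger inhibitor than compound 3, with the step of a 4.0-fold lower number from compound 3 to compound 4 (0.61 log units; beyond the scatter) in this assay estimated to be beyond the scatter. The estimate for compound 4 in this assay is 450 nM, within a range of 100 nM to 2000 nM.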

Compound 4, half-maximal inhibitory concentration: 39.8 nM
The estimate for compound 4 lay 11-fold (1.05 log units) above the measured number, and the stated range ends above it.
By their numbers in this assay, from the lowest: compound 4; then compound 2; then compound 1; then compound 3.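

In this assay, putting acetyl in place of (ethoxycarbonyl)methoxy on this aromatic carbon, opposite the ring oxygen, gives a 46-fold lower number from compound 3 to compound 4 (1.66 log units; beyond the scatter) while the rest of the structure stays the same. This is the first pair shown that differs in one place only, so it isolates this position and shows that the group held there can change the number by a large step; compound 1 and compound 2 each differ from compound 3 in more than one place and could not show this. The change replaces a side chain of 7 heavy atoms and 3 hydrogen-bond acceptors with one of 3 heavy atoms and 1 acceptor, but no separate measurement connects any of these differences to the step.

Going by these compounds, what remains open is whether shortening the side chain, removing its ester, or placing a carbonyl directly on the aromatic carbon matters most, and a longer ketone chain, an amine or a carboxylic acid at this position would help separate these possibilities. On these data alone, it is also open whether acetyl would give a similar step with a different group on the benzyl ring, such as the bromine in compound 2.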